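Thiourea ester series: tert-butyl ester at thiophen-3-yl

The source may report more compounds than this note shows. Statements on the series, on what has been measured and on what is new or still open speak of the compounds shown alone.

Measured so far in an assay on membranes from HeLa cells for displacement of a labelled ligand from adenosine receptor A3 (Homo sapiens), read by scintillation counting, with a stated time of 180 min, tested at 1 uM; on this read-out lower numbers stand for less inhibition and higher numbers for more inhibition at the one concentration tested (going by the name of the read-out):
- compound 1 `CC1=C(C(=O)OC(C)(C)C)C(c2ccco2)NC(=S)N1`: 9%
- compound 2 `COC(=O)C1=C(C)NC(=S)NC1c1cccs1`: 1%
- compound 3 `COC(=O)C1=C(C)NC(=S)NC1c1ccsc1`: 3%

Compound 3 sits second of the three numbers, with compound 2 nearest and compound 1 furthest; both gaps lie within the scatter, so the three compounds cannot be ordered on these numbers. Among the measured compounds shown here, the one step between compounds differing in a single place, a number 2 percentage points higher from compound 2 to compound 3 (within the scatter), is likewise within the scatter, so thiophen-3-yl in place of thiophen-2-yl on a saturated ring carbon changed nothing that can be read.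

Compound 4 `CC1=C(C(=O)OC(C)(C)C)C(c2ccsc2)NC(=S)N1` is compound 3 with the change (tert-butyl in place of methyl on an oxygen next to a carbonyl group). For the measured compounds named here, no measured single-place step touches this change. Compound 1 does carry tert-butyl on the oxygen next to the carbonyl group and gives 9%, but it differs from compound 2 in two places, so its number only shows that a tert-butyl ester in this series has so far stayed low in this assay.

Going by the values given here, with no bearing step and every measured number low, the step of a number 3 percentage points higher from compound 3 to compound 4 (within the scatter) is expected to stay within the scatter, with no direction claimed. Compound 4 is therefore estimated at 6%, with a range from -5% to 20% in this assay.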

Compound 4, a percentage reported as inhibition, at one concentration (the size of the read-out at that concentration, not a potency): 16%
Compound 4: the middle estimate sits 10 percentage points below what was measured; the range from low to high includes it.
By their numbers in this assay, from the lowest: compounds 2, 3, 1 and 4 (each within the scatter of the next, the first and the last beyond it).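

In this assay, among the compounds shown here, the ester position gives the first single-place step in this set that can be read: tert-butyl in place of methyl on an oxygen next to a carbonyl group yields a number 13 percentage points higher from compound 3 to compound 4 (beyond the scatter) in the thiophen-3-yl compounds. For the compounds shown here, with the tert-butyl ester held constant, thiophen-3-yl in place of furan-2-yl on a saturated ring carbon yields a number 7 percentage points higher from compound 1 to compound 4 (within the scatter) and so shows no readable effect of that swap, which leaves the ester as the only change here with a readable step, and a modest one at a single concentration. No supporting data bear on what lies behind the ester step.

On these data alone, whether the step is specific to tert-butyl remains open, as an ethyl or isopropyl ester, a carboxylic acid or a primary amide at the same place would be needed to show how the read-out follows the group there. Also open, as far as these compounds go, is whether the ester step carries over to other ring substituents, which a thiophen-2-yl compound with the tert-butyl ester would test directly against compound 2.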